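Propylamino Gives Way to Dimethylamino

This account rests on a few compounds, and the source may have more. Where it says the series, first, only, none or still open, it means among the compounds named here.

Of the compounds shown here, three have so far been measured in a physicochemical assay for lipophilicity; on this read-out lower numbers stand for lower lipophilicity and higher numbers for higher lipophilicity. Compound 1 `CCN(CC)c1c(C)n(-c2ccccc2)c(=O)n(C)c1=O` gives 2.19, compound 3 `CCn1c(=O)c(N(C)C)c(C)n(-c2ccccc2)c1=O` gives 2.29, and compound 2 `CCCNc1c(C)n(C)c(=O)n(-c2ccccc2)c1=O` gives 1.2, the lowest of the three, with compound 1 nearest and compound 3 furthest, both beyond the scatter. Compound 4 `Cc1c(N(C)C)c(=O)n(-c2ccccc2)c(=O)n1C` has not yet been measured. It differs from compound 2 in one place: dimethylamino in place of propylamino on an aromatic carbon. For the measured compounds named here, no step between two measured compounds that differ in a single place is available, so the size of the move is judged from compound 3, which also carries a dimethylamino group and gives 2.29. An upward step beyond the scatter is expected, a number 0.70 log units higher from compound 2 to compound 4 (beyond the scatter). Compound 4 is estimated at 1.9, between 1.4 and 2.4.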

Compound 4, partition coefficient: 1.3
Estimate against measurement, compound 4: 0.60 log units above, and the stated range ends above it.
By their numbers in this assay, from the lowest: compounds 2 and 4 (each within the scatter of the next); then compounds 1 and 3 (each within the scatter of the next).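

In this assay, dimethylamino in place of propylamino on this aromatic carbon gives a number 0.10 log units higher from compound 2 to compound 4 (within the scatter), the first single-place comparison available at this position. The exchange therefore does not separate the two groups on this read-out, even though the entering group has 0 hydrogen-bond donors and the leaving group has 1.

As far as these compounds go, whether a longer chain, such as dibutylamino, or a carboxylic acid at this position would also stay within the scatter of compound 2 remains open. Nothing shown accounts for how close the two groups lie.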